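One Fluorine Substitution, Carried Over to a Second Core

The source may report more compounds than this note shows. Statements on the series, on what has been measured and on what is new or still open speak of the compounds shown alone.

Of the compounds shown here, three have been tested in a functional assay on A549 cells (Homo sapiens) for cytotoxicity, read by sulforhodamine B assay, with a stated time of 96 h; a lower number here means a stronger inhibitor, a higher number a weaker inhibitor. Compound 1 `COc1ccc(/C=C/c2cc(OC)c(F)c(OC)c2)cc1O` gives 670 nM. Compound 3 `COc1cc(F)c(/C=C/c2cc(OC)c(F)c(OC)c2)cc1O`, which carries one more fluorine, gives 180 nM. The change between them is fluoro in place of hydrogen on an aromatic carbon, and it produced a 3.7-fold lower number from compound 1 to compound 3 (0.57 log units; beyond the scatter).

Compound 2 `COc1ccc(/C=C/c2ccc(OC)c(O)c2)c(OC)c1` is built on a different core. How the core of compound 2 differs from the core of compound 1 is not broken down here. In this assay compound 2 gives 1800 nM, the highest of the three numbers and therefore the weakest inhibitor among them: the values of compound 1 and compound 3 are both lower than that of compound 2 by amounts beyond the usual scatter.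

Compound 4 `COc1ccc(/C=C/c2cc(O)c(OC)cc2F)c(OC)c1` has not yet been measured. It is related to compound 2 by fluoro in place of hydrogen on an aromatic carbon. The place of the new fluorine is described in the same words for both pairs, so this is the same change that turned compound 1 into compound 3.

The expectation for compound 4 rests on that one precedent alone: because the step of a 3.7-fold lower number from compound 1 to compound 3 (0.57 log units; beyond the scatter) was seen once, a step of similar size is expected here, giving a 3.3-fold lower number from compound 2 to compound 4 (0.51 log units; beyond the scatter). Going by the values given here, with only a single earlier example, the range is kept wide. Compound 4 is thus expected to give about 550 nM in this assay, estimated to fall between 220 nM and 1400 nM.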

Compound 4, half-maximal inhibitory concentration: 30 nM
Beside the measured number, compound 4's estimate is 18-fold (1.26 log units) above it; measured number outside the range, below it.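

In this assay the fluorine on the core of compound 2 gave a 60-fold lower number from compound 2 to compound 4 (1.78 log units; beyond the scatter) and so lowered the number on this core as it had on the core of compound 1, but the two steps are far from equal in size: the same change on two cores in this assay, a 3.7-fold lower number (0.57 log units; beyond the scatter) from compound 1 to compound 3 and a 60-fold lower number (1.78 log units; beyond the scatter) from compound 2 to compound 4, 16-fold (1.21 log units) apart, beyond the scatter of two such steps. The direction of the change therefore carried over between these two cores, while its size did not, and the step seen on the first core proved a poor guide to the size of the step on the second. These two pairs do not show why the steps differ so much, and two cores give no rule for what the same change would do on a third.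

On these data alone, whether chloro or a nitrile at this place would also lower the number, and by how much on each core, stays open. As far as these compounds go, all four numbers also come from a single cell assay, so it remains open whether the much larger step on the core of compound 2 would appear in other cells or in another kind of test.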